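The source may report more compounds than this note shows. Statements on the series, on what has been measured and on what is new or still open speak of the compounds shown alone.

Measured so far:
compound 1 `C[C@H](c1ccc(F)cc1)N(Cc1cccc(C(=O)O)c1)C(=O)c1cc2ccccn2n1`, 325 uL/min in an ADME assay (liver) for metabolic stability, with Liver microsome (Rattus norvegicus) as the target, using microsomes; a higher number here means faster removal of the compound, a lower number slower removal
compound 2 `C[C@H](c1ccc(F)cc1)N(Cc1cccc(C(=O)O)c1)C(=O)c1cc2ccccc2nn1`, 76 uL/min

Within the data shown here, compound 2 stands lowest of the two numbers; the single measured step, a 4.3-fold lower number from compound 1 to compound 2 (0.63 log units; beyond the scatter), lies beyond the scatter. Compound 3 `C[C@H](c1ccc(F)cc1)N(Cc1cccc(C(=O)O)c1)C(=O)c1cn2ccccc2n1` is not yet measured. The change from compound 2 to compound 3 is a group of 9 heavy atoms (7 carbon, 2 nitrogen; one five-membered aromatic ring with 2 hetero atoms, one six-membered aromatic ring with 1 hetero atom) in place of a group of 10 heavy atoms (8 carbon, 2 nitrogen; one six-membered aromatic ring of carbon only, one six-membered aromatic ring with 2 hetero atoms), on a carbonyl carbon. The step of a 4.3-fold lower number from compound 1 to compound 2 (0.63 log units; beyond the scatter) bears on it: the group entering compound 3 matches the group that compound 1 carries in ring sizes and atom counts, and the change here runs the other way. A rise in this assay is expected, about a 2.6-fold higher number from compound 2 to compound 3 (0.42 log units; beyond the scatter), held smaller than the measured step as the two groups are not identical. For compound 3 the estimate is 200 uL/min, range 80 uL/min to 450 uL/min.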

Compound 3, intrinsic clearance in a liver preparation (reported as CLH), per the amount of preparation that the assay uses in the Liver microsome assay: 113 uL/min
Beside the measured number, compound 3's estimate is 1.8-fold (0.25 log units) above it; the measured number falls inside the stated range.
By their numbers in the Liver microsome assay, from the lowest: compounds 2 and 3 (each within the scatter of the next); then compound 1.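

In the Liver microsome assay, two groups with the same atom counts and ring sizes on the carbonyl carbon still differ, with a 2.9-fold lower number from compound 1 to compound 3 (0.46 log units; beyond the scatter), so those counts alone do not fix the number at this place. Swapping the ring sizes gives a 1.5-fold higher number from compound 2 to compound 3 (0.17 log units; within the scatter), so here that change alone does not separate the two compounds. In a physicochemical assay for lipophilicity (on this read-out higher numbers stand for higher lipophilicity and lower numbers for lower lipophilicity), compound 3 gives 0.6 and compound 2 gives "not determined" (no result reported).

Still open, on these data alone, is how a methyl or chlorine substituent on the group at this place would move the number. Nothing shown gives a cause for either step.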